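The compounds below may be only part of what the source reports. "The series", "measured", "known", "first", "only" and "open" are said of these compounds alone.

Measured in an ADME assay on H9 cells (Homo sapiens) for cytotoxicity, read by XTT assay, with a stated time of 6 days; a lower number here means that less compound is tolerated, a higher number that more compound is tolerated:
- compound 1 `Cc1cc(Br)cc(C)c1Oc1cc(Nc2ccc(C#N)cc2)c(N)cc1N`: 38400 nM
- compound 2 `Cc1cc(Br)cc(C)c1Oc1ccc(N)c(Nc2ccc(C#N)cc2)c1`: 44600 nM
- compound 3 `Cc1cc(Br)cc(C)c1Oc1cc(Nc2ccc(C#N)cc2)c(N)cc1[N+](=O)[O-]`: 45500 nM; 36400 nM (2 entries)

Compound 1 holds no clear rank in this small set. Its closest comparison is a 1.2-fold higher number from compound 1 to compound 2 (0.07 log units; within the scatter). Compound 3 has no single number, as shown by the several entries of compound 3 in this assay, 45500 nM; 36400 nM (2 entries).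

Compound 4 `Cc1cccc(C)c1Oc1cc(Nc2ccc(C#N)cc2)c(N)cc1N` differs from compound 1 at one place: hydrogen in place of bromo on an aromatic carbon. The 4-bromo-2,6-dimethylphenyl group becomes 2,6-dimethylphenyl.

Among the measured compounds shown here, no measured step covers the loss of bromo. For the measured compounds named here, the only step available is a different change, hydrogen in place of amino on an aromatic carbon, and it gave a 1.2-fold higher number from compound 1 to compound 2 (0.07 log units; within the scatter). That offers only indirect guidance, so the range stays wide.

The expected result is a 1.1-fold higher number from compound 1 to compound 4 (0.04 log units; within the scatter), which means no expected step beyond the scatter and no favoured direction. For compound 4 the estimated value in this assay is 42000 nM, with an expected range of 20000 nM to 90000 nM.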

Compound 4, half-maximal cytotoxic concentration: 53200 nM
Estimate against measurement, compound 4: 1.3-fold (0.10 log units) below, within the range that was stated.
By their numbers in this assay, from the lowest: compounds 1, 2 and 4 (each within the scatter of the next).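

Up to compound 4, the only single change on record lay on the shared core, so the outer 4-bromo-2,6-dimethylphenyl group had not been tested; this step is the first reading at the place para to a large group. In this assay, the change to 2,6-dimethylphenyl gives a 1.4-fold higher number from compound 1 to compound 4 (0.14 log units; within the scatter), so bromo at this place is not needed to keep the number in the range of the other compounds, and hydrogen serves as a simpler reference point for the series. Nothing in the data shown bears on a cause for this step.

With only bromo and hydrogen shown at this place, it remains open whether an amine, a carboxylic acid or a longer chain there would shift the number beyond the scatter. Also open, on these data alone, is whether the same exchange of bromo for hydrogen reads alike on the cores of compound 2 and compound 3.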